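The source may hold more compounds than are shown below. What is called first, only, known or untested is meant among the compounds shown, and "the series" means these compounds.

Among the compounds with values here, compound 1, `Nc1nc(=O)ccn1[C@@H]1O[C@H](COP(=O)(O)O)[C@@H](O)[C@H]1O`, is the first of the two measured compounds in an in vitro functional assay on 1321-N1 cells for agonist activity at P2Y purinoceptor 2 (Homo sapiens), read by scintillation proximity assay and inositol phosphate accumulation; a higher number here means that more compound is needed for the effect, a lower number that less compound is needed. In this assay compound 1 reaches only the limit of > 100000 nM, which is a limit of the assay and not a number. Compound 2, `COc1nc(=O)ccn1[C@@H]1O[C@H](COP(=O)(O)O)[C@@H](O)[C@H]1O`, carries a methoxy in place of the amino on an aromatic carbon; in this assay compound 2 gives 9900 nM. Within the data shown here, the only step among the measured compounds, an at least 10-fold lower number from compound 1 to compound 2 (1.00 log units; beyond the scatter), is stated as a limit-bound change, since one of the two values sits at the limit of > 100000 nM in this assay, at which 1 of the 2 values shown sits. Among the measured compounds shown here, compound 2 therefore stands as the only compound with a measured number in this assay.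

Compound 3, `O=c1ccn([C@@H]2O[C@H](COP(=O)(O)O)[C@@H](O)[C@H]2O)c(SCCc2ccccc2)n1`, carries phenethylsulfanyl in place of methoxy on an aromatic carbon. For the measured compounds named here, no measured step bears directly on this change; the single measured step concerns a different replacement on the same aromatic carbon and is bounded by a limit, so it gives only a direction for that earlier change, not a size for this one. On this basis the author expects for compound 3 a step of about a 3.3-fold lower number from compound 2 to compound 3 (0.52 log units; beyond the scatter) toward a lower number in this assay, with wide uncertainty. Compound 3 is estimated at 3000 nM, within a range from 500 nM to 30000 nM.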

Compound 3, half-maximal effective concentration: 1300 nM
Compound 3: middle estimate off by 2.3-fold (0.36 log units), on the high side; the measured number falls inside the stated range.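

In this assay, the aromatic carbon between two ring nitrogen atoms accepts a much larger group than methoxy, and phenethylsulfanyl, with its six-membered aromatic ring of carbon only, gives a 7.6-fold lower number from compound 2 to compound 3 (0.88 log units; beyond the scatter). Within the data shown here, this is the only step here between two measured numbers, so it gives this position a size of change that the earlier comparison could not. Measured against amino, the same group gives an at least 76-fold lower number from compound 1 to compound 3 (1.88 log units; beyond the scatter), and the value of compound 1 is a limit of the assay and not a number, so this step gives only a lower bound: the limit of > 100000 nM in this assay, at which 1 of the 3 values shown sits.

The compounds shown do not tell whether the step from methoxy to phenethylsulfanyl belongs to the sulfur, the two-carbon chain or the phenyl ring, a question that methylsulfanyl, benzylsulfanyl and 2-phenylethoxy groups at this carbon would separate. From the compounds shown here alone, it also remains open how the number in this assay would respond to a longer chain ending in phenyl, or to a chloro or methoxy group on that phenyl ring.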